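The source may report more compounds than this note shows. Statements on the series, on what has been measured and on what is new or still open speak of the compounds shown alone.

In a physicochemical assay for permeability, using PAMPA, at pH 4 (a higher number here means that the compound crosses the layer faster, a lower number that the compound crosses the layer more slowly), compound 1 `Cc1ccc2nc(NC(C)C)nc(NCc3ccco3)c2c1` gives 67.2 10^-6 cm/s.
In this assay compound 2 `Cc1cccc2nc(NC(C)C)nc(NCc3ccco3)c12` gives 45.9 10^-6 cm/s.
In this assay compound 3 `COc1ccc2nc(NC(C)C)nc(NCc3ccco3)c2c1` gives 80.2 10^-6 cm/s.

The three values lie close to one another, and none of the gaps between them reaches beyond the usual scatter of this assay. Compound 1 and compound 2 are built from the same atoms joined differently; the difference between the two cores is not broken down here. Compound 3 arises from compound 1 by methoxy in place of methyl on an aromatic carbon, and this gave a 1.2-fold higher number from compound 1 to compound 3 (0.08 log units; within the scatter).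

Compound 4 `COc1cccc2nc(NC(C)C)nc(NCc3ccco3)c12` has not yet been measured. It arises from compound 2 by methoxy in place of methyl on an aromatic carbon. Going by the values given here, this is the same kind of change as the one from compound 1 to compound 3, though the place is not quite the same: in compound 1 the carbon is meta to a fused ring and para to a fused ring, in compound 2 it is ortho to a fused ring and meta to a fused ring. Because a 1.2-fold higher number from compound 1 to compound 3 (0.08 log units; within the scatter) stayed within the scatter, the step is expected to be equally modest, a 1.2-fold higher number from compound 2 to compound 4 (0.08 log units; within the scatter). Compound 4 is therefore expected to give about 55 10^-6 cm/s, most likely between 32 10^-6 cm/s and 95 10^-6 cm/s.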

Compound 4, apparent permeability: 87 10^-6 cm/s
Compound 4: the middle estimate sits 1.6-fold (0.20 log units) below what was measured; the measured number falls inside the stated range.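

In this assay, methoxy in place of methyl on an aromatic carbon gave a 1.9-fold higher number from compound 2 to compound 4 (0.28 log units; within the scatter) and, on the other core, a 1.2-fold higher number from compound 1 to compound 3 (0.08 log units; within the scatter); the swap therefore stayed within the usual scatter on both cores, even though its place on the ring is not quite the same. This shows that, for these two pairs, the result on one core gave a fair guide to the result on the other, but it does not show that methoxy truly raises the number, nor that the step has the same size on both cores, and two pairs cannot establish a rule for the series. Nothing measured here explains these numbers.

The compounds shown leave open whether a different group on this aromatic carbon, such as an amine, a carboxylic acid or a longer chain, would give a step beyond the scatter. They also leave open whether methoxy in place of methyl would stay as modest on further cores.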